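Replacing the Aryl Group of Compound 3

The compounds below may be only part of what the source reports. "The series", "measured", "known", "first", "only" and "open" are said of these compounds alone.

Of the compounds shown here, three sharing one core have been tested in a functional assay on PC-3 cells (Homo sapiens) for cytotoxicity, read by sulforhodamine B assay, with a stated time of 48 h; a lower number here means a stronger inhibitor, a higher number a weaker inhibitor. Compound 1 `C[C@H]1CC[C@@H]2[C@@H](OC(=O)[C@]23CC(c2ccc(N(C)C)cc2)=NO3)[C@]2(C)C(=O)C=C[C@@]12O` gives 6300 nM, compound 2 `C[C@H]1CC[C@@H]2[C@@H](OC(=O)[C@]23CC(c2ccccc2[N+](=O)[O-])=NO3)[C@]2(C)C(=O)C=C[C@@]12O` gives 37000 nM, and compound 3 `COc1cc(C2=NO[C@]3(C2)C(=O)O[C@@H]2[C@H]3CC[C@H](C)[C@]3(O)C=CC(=O)[C@@]23C)ccc1O` gives 16000 nM. Compound 3 therefore holds the second highest of the three numbers. Next comes compound 4 `Cc1ccccc1C1=NO[C@]2(C1)C(=O)O[C@@H]1[C@H]2CC[C@H](C)[C@]2(O)C=CC(=O)[C@@]12C`, in which 2-methylphenyl takes the place of 4-hydroxy-3-methoxyphenyl on a carbon with a double bond to nitrogen (2-methylphenyl in place of 4-hydroxy-3-methoxyphenyl on a carbon with a double bond to nitrogen). All three measured steps changed the group at this same place: a 5.9-fold higher number from compound 1 to compound 2 (0.77 log units; beyond the scatter), a 2.5-fold higher number from compound 1 to compound 3 (0.40 log units; beyond the scatter) and a 2.3-fold lower number from compound 2 to compound 3 (0.36 log units; beyond the scatter). Each is modest, though beyond the scatter. Among the measured compounds shown here, no measured compound carries 2-methylphenyl, and the nearest match by name is the 2-nitrophenyl group of compound 2, at 37000 nM. A small move toward that higher number is therefore expected in this assay, probably not beyond the scatter. The estimated change is a 1.4-fold higher number from compound 3 to compound 4 (0.14 log units; within the scatter). For compound 4 the estimated value is 22000 nM, with an expected range from 8000 nM to 55000 nM.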

Compound 4, half-maximal inhibitory concentration: 10000 nM
Beside the measured number, compound 4's estimate is 2.2-fold (0.34 log units) above it; low and high end bracket the measured number.
By their numbers in this assay, from the lowest: compounds 1, 4 and 3 (each within the scatter of the next, the first and the last beyond it); then compound 2.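

In this assay, the all-carbon 2-methylphenyl group gives a 1.6-fold lower number from compound 3 to compound 4 (0.20 log units; within the scatter) and also a 1.6-fold higher number from compound 1 to compound 4 (0.20 log units; within the scatter), so compound 4 stays within the scatter of both compound 3 and compound 1, although those two lie beyond the scatter of each other. The other new step, methyl in place of nitro on an aromatic carbon, gives a 3.7-fold lower number from compound 2 to compound 4 (0.57 log units; beyond the scatter), which shows that a 2-substituted phenyl at this place need not reach the number of compound 2. No measurement shown explains these differences.

As far as these compounds go, what remains open is how an unsubstituted phenyl, a 2-aminophenyl or a 2-ethylphenyl group would read at this place in this assay. Also open, from the compounds shown here alone, is whether methyl and nitro would differ in the same way on another carbon of the phenyl ring.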